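This account rests on a few compounds, and the source may have more. Where it says the series, first, only, none or still open, it means among the compounds named here.

Compound 3 `COc1cccc(COc2ccccc2OCCNCCOc2c(OC)cccc2OC)c1` gives 61700 nM in a functional assay on PC-3 cells (Homo sapiens) for cytotoxicity, read by sulforhodamine B assay; a higher number here means that more compound is tolerated, a lower number that less compound is tolerated; compound 2 `COc1cccc(OC)c1OCCNCCOc1ccccc1OCc1ccc(C)cc1` gives 61700 nM, and compound 1 `COc1cccc(OC)c1OCCNCCOc1ccccc1OCc1cccc(Cl)c1` gives 58900 nM. Compound 3 thus sits level with compound 2 at the digits shown, and the step of a 1.0-fold higher number from compound 1 to compound 3 (0.02 log units; within the scatter) also stays inside the usual variation. Compound 4 `CCOc1ccc(COc2ccccc2OCCNCCOc2c(OC)cccc2OC)cc1` differs from compound 3 by 4-ethoxyphenyl in place of 3-methoxyphenyl on a saturated chain carbon bound to an oxygen on an aromatic ring. Two measured steps alter the same aryl group at the same place: a 1.0-fold higher number from compound 1 to compound 2 (0.02 log units; within the scatter) and no change at the digits printed from compound 2 to compound 3 (within the scatter). Both fall within the scatter, so for this further swap no step beyond the scatter is expected in this assay in either direction. Compound 4 is therefore estimated at 60000 nM (range 30000 nM to 120000 nM). For compound 4 this amounts to an expected 1.0-fold lower number from compound 3 to compound 4 (0.01 log units; within the scatter).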

Compound 4, concentration lethal to 50% of the cells: 51300 nM
Compound 4: middle estimate off by 1.2-fold (0.07 log units), on the high side; low and high end bracket the measured number.
By their numbers in this assay, from the lowest: compounds 4, 1, 2 and 3 (each within the scatter of the next).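

In this assay, the place on a saturated chain carbon bound to an oxygen on an aromatic ring also takes 4-ethoxyphenyl, of 9 heavy atoms against 8 in 3-methoxyphenyl, with a 1.2-fold lower number from compound 3 to compound 4 (0.08 log units; within the scatter) and a 1.1-fold lower number from compound 1 to compound 4 (0.06 log units; within the scatter). Ethoxy in place of methyl on an aromatic carbon reads the same, with a 1.2-fold lower number from compound 2 to compound 4 (0.08 log units; within the scatter). No supporting data bear on this result.

The compounds shown leave open whether a carboxylic acid or an amine on this phenyl ring, or a longer alkoxy chain, would give a step beyond the scatter.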